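The source may hold more compounds than are shown below. What is called first, only, known or untested is meant among the compounds shown, and "the series" means these compounds.

In a functional assay on the whole organism with Rattus norvegicus as the target (on this read-out lower numbers stand for an effect already at smaller amounts and higher numbers for an effect only at larger amounts of compound), compound 1 `CN(C)C(=O)/C=C1\CCc2ccc(F)cc21` gives 12 mg/kg, and compound 2 `O=C(/C=C1\CCc2ccc(F)cc21)NC1CCCC1` gives 11 mg/kg. Compound 2 therefore stands level with compound 1, as a 1.1-fold lower number from compound 1 to compound 2 (0.04 log units; within the scatter) stays within the scatter. Compound 3 `O=C(/C=C1\CCc2ccc(F)cc21)NCc1ccccc1` keeps the shared core and changes only the group on the amide, with benzyl in place of cyclopentyl on an amide-type nitrogen. Just one measured step bears on this place, the one already given between compound 1 and compound 2, and it showed no change beyond the scatter. Going by the values given here, no measured compound yet carries an aromatic ring there, so this evidence is thin and the range must stay wide. The expected step is an estimated 1.1-fold higher number from compound 2 to compound 3 (0.04 log units; within the scatter), none beyond the scatter. For compound 3 the estimated value is 12 mg/kg, with an expected range from 5 mg/kg to 28 mg/kg.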

Compound 3, dose for half-maximal effect: 8 mg/kg
The estimate for compound 3 lay 1.5-fold (0.18 log units) above the measured number, within the range that was stated.
By their numbers in this assay, from the lowest: compounds 3, 2 and 1 (each within the scatter of the next).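

In this assay, the change from cyclopentyl to benzyl on the amide-type nitrogen is a 1.4-fold lower number from compound 2 to compound 3 (0.14 log units; within the scatter) and so leaves the two compounds level. Going by these compounds alone, this is the first reading for a six-membered aromatic ring of carbon only at this place, and it shows that such a ring, like the five-membered non-aromatic ring of compound 2, gives a number within the scatter of its neighbour. Nothing accompanying these numbers bears on why the change makes so little difference.

From the compounds shown here alone, whether any group on this nitrogen can move the number beyond the scatter remains open. The compounds shown also leave open how a longer chain such as phenethyl, or a group carrying a carboxylic acid or an amine, would read at this place.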